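Fluorophenyl urea series: configuration change at the difluoro stage

This account rests on a few compounds, and the source may have more. Where it says the series, first, only, none or still open, it means among the compounds named here.

Measured so far in an ADME assay on the whole organism with Oryza sativa as the target, tested at 10 uM; on this read-out higher numbers stand for a weaker effect at the one concentration tested and lower numbers for a stronger effect:
- compound 1 `C[C@@H](NC(=O)Nc1cccc(F)c1)c1ccccc1`: 84%
- compound 2 `C[C@H](NC(=O)Nc1cccc(F)c1)c1ccccc1`: 88%
- compound 3 `C[C@@H](NC(=O)Nc1cc(F)cc(F)c1)c1ccccc1`: 96%

Compound 3 stands at the highest of the three numbers in this assay. Compound 2 sits nearest, within the scatter of compound 3, while compound 1 lies furthest, and the step of a number 12 percentage points higher from compound 1 to compound 3 (beyond the scatter) is the only one beyond the scatter, arising from fluoro in place of hydrogen on an aromatic carbon.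

The next compound, compound 4 `C[C@H](NC(=O)Nc1cc(F)cc(F)c1)c1ccccc1`, is not yet measured. It differs from compound 3 as follows: the two compounds have the same atoms and bonds and differ only in configuration as drawn: 1 of 1 stereo elements differ; a stereocentre at a saturated chain carbon is drawn R in compound 3 and S in compound 4

Within the data shown here, the one measured step that bears on this change is a number 4 percentage points higher from compound 1 to compound 2 (within the scatter), which lies within the scatter; this pair is informative because of the fact that compounds 1 and 2 differ only in the configuration as drawn, so it is the closest available precedent for the step from compound 3 to compound 4. On that basis no change beyond the scatter is expected in this assay.

For compound 4 the estimated value in this assay is 97%, with a range from 88% to 104%, which means an expected step of a number 1 percentage points higher from compound 3 to compound 4 (within the scatter).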

Compound 4, a percentage reported as activity, at one concentration (the size of the read-out at that concentration, not a potency): 99%
Estimate against measurement, compound 4: 2 percentage points below, within the range that was stated.
By their numbers in this assay, from the lowest: compounds 1, 2, 3 and 4 (each within the scatter of the next, the first and the last beyond it).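

In this assay the stereocentre at the saturated chain carbon now has a second reading, a number 3 percentage points higher from compound 3 to compound 4 (within the scatter), so the change of drawn configuration stays within the scatter on both cores shown, and this pair isolates that one change: the fact that compounds 3 and 4 differ only in the configuration as drawn. The fluoro in place of hydrogen on an aromatic carbon, earlier read only with the stereocentre drawn R, now also has a reading with it drawn S, a number 11 percentage points higher from compound 2 to compound 4 (beyond the scatter). The two fluoro steps agree, so in these four compounds the size of the fluoro step does not depend on the drawn configuration: the same change on two cores in this assay, a number 12 percentage points higher (beyond the scatter) from compound 1 to compound 3 and a number 11 percentage points higher (beyond the scatter) from compound 2 to compound 4, 1 percentage points apart, within the scatter of two such steps.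

As far as these compounds go, it remains open whether configuration still makes no difference beyond the scatter with a different group on the aromatic ring, such as a nitrile or a methoxy group. The same question stands for a longer chain in place of the methyl on the stereocentre.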